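Melanocortin 4 binding: phenoxyacetyl replacement on compound 2

The compounds below may be only part of what the source reports. "The series", "measured", "known", "first", "only" and "open" are said of these compounds alone.

Measured compounds:
compound 1 `COc1cc(Cl)ccc1C[C@@H](C)C(=O)N1CCN(c2ccc(C)cc2[C@@H](N)CC(C)C)CC1` — 8.1 nM
compound 2 `Cc1cc(CC(C)C(=O)N2CCN(c3ccc(C(F)(F)F)cc3[C@@H](N)CC(C)C)CC2)ccc1Cl` — 71 nM
compound 3 `CC(C)C[C@H](N)c1ccccc1N1CCN(C(=O)[C@H](C)Cc2ccc(Cl)cc2Cl)CC1` — 16 nM

In an assay on HEK293 cells for displacement of a labelled ligand from Melanocortin receptor 4 (Homo sapiens) (on this read-out lower numbers stand for stronger inhibition and higher numbers for weaker inhibition), compound 2 gives the highest of the three numbers; compound 3 stands nearest and compound 1 furthest, both gaps beyond the scatter. Compound 4 `CC(C)C[C@H](N)c1cc(C(F)(F)F)ccc1N1CCN(C(=O)COc2cccc(Cl)c2)CC1` has not been measured in this assay. It differs from compound 2 at the carbonyl carbon attached to the amide-type nitrogen in the ring: (3-chlorophenoxy)methyl in place of 1-(4-chloro-3-methylbenzyl)ethyl on a carbonyl carbon. The 1-(4-chloro-3-methylbenzyl)ethyl group leaves and a (3-chlorophenoxy)methyl group enters, bringing one hydrogen-bond acceptor. Among the measured compounds shown here, no measured pair shows such a change, so the direction is open; the step of a 1.7-fold higher number from compound 2 to compound 4 (0.23 log units; within the scatter) is expected to stay near compound 2, possibly weaker. Compound 4 is estimated at 120 nM, within 25 nM to 600 nM.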

Compound 4, inhibition constant: 2600 nM
The estimate for compound 4 lay 22-fold (1.34 log units) below the measured number, and the stated range ends below it.
By their numbers in this assay, from the lowest: compounds 1 and 3 (each within the scatter of the next); then compound 2; then compound 4.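

In this assay, the step of a 37-fold higher number from compound 2 to compound 4 (1.56 log units; beyond the scatter) comes with (3-chlorophenoxy)methyl in place of 1-(4-chloro-3-methylbenzyl)ethyl on a carbonyl carbon, so binding at this position tolerates this change poorly. Among the compounds shown here, this is the only single-place comparison, and the earlier compounds could not isolate this position. Nothing available here bears on the reason for this loss.

Which part of the exchange carries the loss, the entering oxygen or the other differences between the two groups, remains open. So does how an amine or a longer chain on this carbonyl carbon would behave.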